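Geometry Flip at the Exocyclic Double Bond of Compound 3

This account rests on a few compounds, and the source may have more. Where it says the series, first, only, none or still open, it means among the compounds named here.

Measured in a functional assay on DU-145 cells (Homo sapiens) for inhibition, read by MTT assay, with a stated time of 48 h; a lower number here means a stronger inhibitor, a higher number a weaker inhibitor:
compound 1, `O=C1Nc2ccc(Cl)cc2/C1=C/c1cccc(OCc2cn(Cc3ccccc3)nn2)c1`, gives 24200 nM
compound 2, `O=C1Nc2ccc(Br)cc2/C1=C/c1cccc(OCc2cn(Cc3ccccc3)nn2)c1`, gives 35100 nM
compound 3, `COc1ccc(Cc2ccc3c(c2)/C(=C\c2cccc(OCc4cn(Cc5ccccc5)nn4)c2)C(=O)N3)cc1`, gives > 50000 nM

Compounds 1 and 2 share a core and differ only in the halogen; the step of a 1.5-fold higher number from compound 1 to compound 2 (0.16 log units; within the scatter) is within the scatter, so the two values are read as equal. Compound 3 carries a methoxybenzyl group on the core in place of the halogen, and for compound 3 the value in this assay is a limit rather than a number (the limit of > 50000 nM in this assay, at which 1 of the 3 values shown sits). On the numbers shown, compound 3 therefore sits at the weak end, with no measured value beyond the limit.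

Compound 4, `COc1ccc(Cc2ccc3c(c2)/C(=C/c2cccc(OCc4cn(Cc5ccccc5)nn4)c2)C(=O)N3)cc1`, is the geometric partner of compound 3: the two compounds have the same atoms and bonds and differ only in configuration as drawn: 1 of 1 stereo elements differ; a double bond is drawn E in compound 3 and Z in compound 4. For the measured compounds named here, none of the measured steps concerns a change of double-bond geometry; the only measured step, a 1.5-fold higher number from compound 1 to compound 2 (0.16 log units; within the scatter), is a halogen swap and was within the scatter. Going by the values given here, no step in this set therefore bears on the change from compound 3 to compound 4, and no direction can be inferred from the data.

Compound 4 is accordingly expected to remain near the limit, with an estimated 50000 nM in this assay, ranging from 20000 nM to 120000 nM. The expected step of a number no higher from compound 3 to compound 4 (the limit leaves the size open) is thus estimated as none beyond the scatter, and a second limit is considered likely.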

Compound 4, half-maximal inhibitory concentration: 6700 nM
The estimate for compound 4 lay 7.5-fold (0.87 log units) above the measured number, outside the stated range (below it).
By their numbers in this assay, from the lowest: compound 4; then compounds 1 and 2 (each within the scatter of the next). At a limit, above all of these: compound 3.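

Read in this assay, the change of the double bond from E to Z gives an at least 7.4-fold lower number from compound 3 to compound 4 (0.87 log units; beyond the scatter), which lies beyond the scatter, whereas the halogen swap did not, and nothing else in the structure changes: the fact that compounds 3 and 4 differ only in the configuration as drawn

For compound 3, > 50000 nM is a limit of the assay and not a number.

The 4-methoxybenzyl group, which stood at the weak end while compound 3 alone carried it, now also appears on the compound with the lowest number in the set, with a 5.2-fold lower number from compound 2 to compound 4 (0.72 log units; beyond the scatter) and a 3.6-fold lower number from compound 1 to compound 4 (0.56 log units; beyond the scatter), so the effect of this group on the core cannot be judged apart from the geometry of the double bond.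

The compounds shown leave open whether the chloro and bromo compounds respond to the same change of geometry, and they do not tell why the geometry matters. Going by these compounds, it also remains open how much of the result depends on the methoxy group itself, which a plain benzyl group, a 4-hydroxybenzyl group or a 4-aminobenzyl group at the same place on the core could help to settle.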